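Swapping the aryl group from compound 2 to compound 3

The compounds below may be only part of what the source reports. "The series", "measured", "known", "first", "only" and "open" are said of these compounds alone.

Compound 1 `CCC1=C(O)c2c(oc(-c3ccc(F)cc3)cc2=O)C(CC)(CC)C1=O`: 33 uM
Compound 2 `CCC1=C(O)c2c(oc(-c3ccc(COC)cc3)cc2=O)C(CC)(CC)C1=O`: > 52.4 uM (a limit)

In a functional assay on KB cells (Homo sapiens) for antiproliferative activity, read by sulforhodamine B assay, with a stated time of 3 days (on this read-out lower numbers stand for an effect already at smaller amounts and higher numbers for an effect only at larger amounts of compound), compound 2 gives no number, only the limit > 52.4 uM. Compound 3 `CCC1=C(O)c2c(oc(-c3ccc(C)c(C)c3)cc2=O)C(CC)(CC)C1=O` differs from it as follows: 3,4-dimethylphenyl in place of 4-(methoxymethyl)phenyl on an aromatic carbon. That is, 3,4-dimethylphenyl takes the place of 4-(methoxymethyl)phenyl. Within the data shown here, the only measured step bearing on this is an at least 1.5-fold higher number from compound 1 to compound 2 (0.20 log units; that floor lies within the scatter), which gives a floor and no firm size. Among the measured compounds shown here, compound 1, at 33 uM, offers the only true number, so a modest step towards a lower number is expected in this assay. The expected step is an at least 1.3-fold lower number from compound 2 to compound 3 (0.11 log units; that floor lies within the scatter). For compound 3 the estimated value is 40 uM, with an expected range of 18 uM to 80 uM.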

Compound 3, concentration for half-maximal effect: 35.5 uM
For compound 3 the middle estimate is 1.1-fold (0.05 log units) above the measured one; the range from low to high includes it.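

In this assay, the change to 3,4-dimethylphenyl gives an at least 1.4-fold lower number from compound 2 to compound 3 (0.16 log units; that floor lies within the scatter), and this position now has two aryl groups with true numbers. The move from 4-fluorophenyl gives a 1.1-fold higher number from compound 1 to compound 3 (0.03 log units; within the scatter), so these two groups cannot be told apart on this read-out. Compound 2 remains a limit and not a number, so the true size of its step to compound 3 stays unknown: the limit of > 52.4 uM in this assay, at which 1 of the 3 values shown sits.

The compounds shown leave open whether an amine or a carboxylic acid on this aryl ring would shift the number beyond the scatter.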